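The source may report more compounds than this note shows. Statements on the series, on what has been measured and on what is new or still open speak of the compounds shown alone.

Measured compounds:
compound 1 `CC(=O)Nc1ccc(S(=O)(=O)NNC(=O)c2cccnc2Nc2ccc(Cl)cc2)cc1` with > 100000 nM
compound 2 `O=C(NNS(=O)(=O)c1ccc(F)cc1)c1cccnc1Nc1ccc(Cl)cc1Cl` with > 100000 nM

Compound 1 carries the structure `CC(=O)Nc1ccc(S(=O)(=O)NNC(=O)c2cccnc2Nc2ccc(Cl)cc2)cc1`. In a functional assay on Hs-578T cells (Homo sapiens) for antiproliferative activity (on this read-out lower numbers stand for stronger inhibition of growth and higher numbers for weaker inhibition of growth), compound 1 gives > 100000 nM, which is a limit of the assay and not a number. Among the compounds with values here, compound 2, with the structure `O=C(NNS(=O)(=O)c1ccc(F)cc1)c1cccnc1Nc1ccc(Cl)cc1Cl`, shares much of this core and is the only other compound measured in this assay; for compound 2 the result is > 100000 nM, again a limit. Both measured values therefore sit at the same limit, as the evidence shows: the limit of > 100000 nM in this assay, at which 2 of the 2 values shown sit. Within the data shown here, no step between measured compounds can be taken from two limits.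

Compound 3 has the structure `O=C(NNS(=O)(=O)c1ccc(Cl)cc1Cl)c1cccnc1Nc1ccc(Cl)cc1`. It differs from compound 1 in one place: 2,4-dichlorophenyl in place of 4-acetamidophenyl on a sulfonyl sulfur. The part that enters here is the same 2,4-dichlorophenyl that compound 2 carries on its sulfonyl sulfur, and compound 2 stood at the limit. With both measured values at the limit, the step from compound 1 to compound 3 is expected to be none beyond the scatter, a number no higher from compound 1 to compound 3 (the limit leaves the size open). Compound 3 is therefore estimated to give 100000 nM in this assay, within the range 30000 nM to 300000 nM, most probably again reported only as a limit.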

Compound 3, concentration for total growth inhibition: 41700 nM
Estimate against measurement, compound 3: 2.4-fold (0.38 log units) above; measured number inside the range.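

In this assay, 2,4-dichlorophenyl in place of 4-acetamidophenyl on a sulfonyl sulfur gives an at least 2.3-fold lower number from compound 1 to compound 3 (0.37 log units; beyond the scatter), the first step that can be read among the compounds shown. The earlier compounds shown here showed only that the read-out could stay at its limit. This pair shows that the group on the sulfonyl sulfur can, with the rest of the core of compound 1 unchanged, bring the read-out to a real number: compound 3 gives 41700 nM. The full size of the step stays unknown, since the value of compound 1 is a limit of the assay and not a number: the limit of > 100000 nM in this assay, at which 2 of the 3 values shown sit.

This single pair cannot separate the loss of 4-acetamidophenyl from the entry of 2,4-dichlorophenyl, so it leaves open whether the acetamido group or the two chlorine atoms account for the step. Also open, from the compounds shown here alone, is how a plain phenyl, or a phenyl carrying a single chlorine, an amine or a carboxylic acid, on the same sulfonyl sulfur would compare with compound 3.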